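Iodo in place of bromo on a urea pair

The source may report more compounds than this note shows. Statements on the series, on what has been measured and on what is new or still open speak of the compounds shown alone.

Compound 2 `C[C@H](NC(=O)Nc1ccccc1Br)c1ccccc1` has been measured alongside compound 1 `CC(=O)c1ccccc1NC(=O)N[C@@H](C)c1ccccc1` in an ADME assay on the whole organism with Oryza sativa as the target, tested at 1 uM; a lower number here means a stronger effect, a higher number a weaker effect of the compound at the concentration tested. Compound 2 gives 99%, and compound 1 gives 97% in this assay, the two numbers lying within the usual scatter of each other. Within the data shown here, the single measured step, a number 2 percentage points higher from compound 1 to compound 2 (within the scatter), is thus within the scatter. Compound 3 `C[C@H](NC(=O)Nc1ccccc1I)c1ccccc1` differs from compound 2 by iodo in place of bromo on an aromatic carbon. Among the measured compounds shown here, with only one step, itself within the scatter, as a guide, no change beyond the scatter is expected in this assay. Compound 3 is therefore estimated at 98%, in the range 90% to 100%. That corresponds to an expected step of a number 1 percentage points lower from compound 2 to compound 3 (within the scatter).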

Compound 3, a percentage reported as activity, at one concentration (the size of the read-out at that concentration, not a potency): 100%
The estimate for compound 3 lay 2 percentage points below the measured number, and the stated range covers the measured number.
By their numbers in this assay, from the lowest: compounds 1, 2 and 3 (each within the scatter of the next).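

In this assay, iodo in place of bromo on this aromatic carbon gives a number 1 percentage points higher from compound 2 to compound 3 (within the scatter), and iodo in place of acetyl gives a number 3 percentage points higher from compound 1 to compound 3 (within the scatter). A third group at this place, ortho to a large group, thus still leaves the read-out within the scatter of the other two, so the swaps among these groups show no effect here. No measured evidence bears on why this is so. From the compounds shown here alone, it remains open whether an amine, a carboxylic acid or a plain hydrogen at this place would move the number beyond the scatter.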